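The source may report more compounds than this note shows. Statements on the series, on what has been measured and on what is new or still open speak of the compounds shown alone.

Three compounds of a shared core were tested in a toxicity assay on the whole organism (J774 cells) for cytotoxicity, with Mus musculus as the target, read by MTT assay, with a stated time of 24 h, tested at 10 uM; on this read-out lower numbers stand for a stronger effect and higher numbers for a weaker effect at the one concentration tested. Compound 1, `CCCCCCCCCO[C@@H]1[C@@H](N)[C@@H](O[C@H]2[C@H](O)[C@@H](O)[C@H](N)C[C@@H]2N)O[C@H](CN)[C@H]1OCCCCCCCCC`, gives 82.7%. Compound 2, `NC[C@H]1O[C@H](O[C@H]2[C@H](O)[C@@H](O)[C@H](N)C[C@@H]2N)[C@H](N)[C@@H](OCCCc2ccc3ccccc3c2)[C@@H]1OCCCc1ccc2ccccc2c1`, gives 87.7%, and compound 3, `NC[C@H]1O[C@H](O[C@H]2[C@H](OCCCc3ccc4ccccc4c3)[C@@H](O)[C@H](N)C[C@@H]2N)[C@H](N)[C@@H](OCCCc2ccc3ccccc3c2)[C@@H]1O`, gives 91.1%. Compound 1 reports the smallest of the three numbers, but its gap to compound 2 and its gap to compound 3 both fall within the usual scatter of repeated measurements, so the three read alike and none can be called stronger or weaker than another.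

Compound 4, `CCCCCCCCCO[C@@H]1[C@@H](N)[C@@H](OC[C@@H](O)CN)O[C@H](CN)[C@H]1OCCCCCCCCC`, has not yet been measured. It differs from compound 1 by 3-amino-2-hydroxypropyl in place of 4,6-diamino-2,3-dihydroxycyclohexyl on an oxygen on a saturated carbon. Among the measured compounds shown here, no measured pair shows the effect of such a change, so there is no step to lean on; what is known is only that all three measured compounds sit close together.

The step of a number 2.3 percentage points higher from compound 1 to compound 4 (within the scatter) is expected to stay within the scatter, in no clear direction. Compound 4 is therefore estimated at 85%, with a range from 72% to 98% in this assay .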

Compound 4, a percentage reported as activity, at one concentration (the size of the read-out at that concentration, not a potency): 85.1%
Beside the measured number, compound 4's estimate is 0.1 percentage points below it; low and high end bracket the measured number.
By their numbers in this assay, from the lowest: compounds 1, 4, 2 and 3 (each within the scatter of the next).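

In this assay, putting 3-amino-2-hydroxypropyl in place of 4,6-diamino-2,3-dihydroxycyclohexyl on an oxygen on a saturated carbon gives a number 2.4 percentage points higher from compound 1 to compound 4 (within the scatter). Among the compounds shown here, this is the first measured step at this place, and it shows that the six-membered ring of 10 heavy atoms can be exchanged for an open chain of 5 heavy atoms with no ring without moving the number beyond the scatter. No available evidence explains this result.

As far as these compounds go, it remains open whether another group on this oxygen, such as a carboxylic acid or a longer chain ending in an amine, would move the number beyond the scatter. From the compounds shown here alone, it also remains open whether the same exchange would read alike on compound 2, which carries different chains on the shared core.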